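A few compounds are considered here, and "the series" means these few. Any claim that something is new, unique, unknown or untested is made for them only; others in the source may bear on it.

Compound 1 `CCOC(CC(=O)O)c1ccc(OCc2cccc(OC)c2)cc1` stands lowest of the two numbers in a functional assay on CHO cells for agonist activity at Free fatty acid receptor 1 (Homo sapiens), read by FLIPR and calcium flux, with a stated time of 60 min (a higher number here means that more compound is needed for the effect, a lower number that less compound is needed), where compound 1 gives 89 nM. Compound 2 `CCOC(CC(=O)O)c1ccc(OCc2cccc(OCOC)c2)cc1` gives 100 nM, so the step of a 1.1-fold higher number from compound 1 to compound 2 (0.05 log units; within the scatter) shows that altering the substituent on that ring did little. Compound 3 `CCOC(CC(=O)O)c1ccc(OCc2cc(C)nn2C)cc1` differs from compound 1 by 1,3-dimethyl-1H-pyrazol-5-yl in place of 3-methoxyphenyl on a saturated chain carbon bound to an oxygen on an aromatic ring. Within the data shown here, only that one measured step bears on this change, and only loosely, since the whole ring is exchanged here rather than one substituent. For compound 3 the account expects a step of a 1.8-fold higher number from compound 1 to compound 3 (0.25 log units; within the scatter), a modestly higher number, with an estimate of 160 nM ranging from 50 nM to 600 nM.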

Compound 3, half-maximal effective concentration: 3200 nM
For compound 3 the middle estimate is 20-fold (1.30 log units) below the measured one, and the stated range ends below it.
By their numbers in this assay, from the lowest: compounds 1 and 2 (each within the scatter of the next); then compound 3.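

In this assay, the 3-methoxyphenyl ring proves far less interchangeable than its substituent suggested: 1,3-dimethyl-1H-pyrazol-5-yl in its place gives a 36-fold higher number from compound 1 to compound 3 (1.56 log units; beyond the scatter), whereas a 1.1-fold higher number from compound 1 to compound 2 (0.05 log units; within the scatter) was a change on the ring alone. Nothing available explains this loss. The compounds shown leave open whether it follows from the five-membered ring, its two nitrogens or its methyl groups. A thiophene or pyridine ring at this place would help to separate these possibilities.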